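The source may report more compounds than this note shows. Statements on the series, on what has been measured and on what is new or still open speak of the compounds shown alone.

Measured in a functional assay on PC-3 cells (Homo sapiens) for cytotoxicity, read by sulforhodamine B assay, with a stated time of 48 h; on this read-out higher numbers stand for weaker inhibition and lower numbers for stronger inhibition:
- Compound 1 `CC(=O)N1N=C(c2cccc([N+](=O)[O-])c2)CC1c1ccccc1`: 8710 nM
- Compound 2 `O=CCN1N=C(c2ccc3ccccc3c2)CC1c1cccc([N+](=O)[O-])c1`: 2980 nM

Compound 2, at 2980 nM, has the lower of the two numbers, and the gap to compound 1 lies beyond the usual scatter. Compound 3 `O=CCN1N=C(c2ccc3ccccc3c2)CC1c1cccc(Br)c1` has not yet been measured. It keeps the rest of compound 2 but has bromo in place of nitro on an aromatic carbon, a change from 3-nitrophenyl to 3-bromophenyl: bromo in place of nitro on an aromatic carbon. Among the compounds with values here, no measured pair shows this swap, so the data give no direct guide, and no step beyond the scatter is expected in this assay. The expected change is a 1.1-fold lower number from compound 2 to compound 3 (0.04 log units; within the scatter). The estimate for compound 3 is 2700 nM, with an expected range of 900 nM to 8000 nM.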

Compound 3, half-maximal inhibitory concentration: 10900 nM
Estimate against measurement, compound 3: 4.0-fold (0.61 log units) below; the whole stated range lies below it.
By their numbers in this assay, from the lowest: compound 2; then compounds 1 and 3 (each within the scatter of the next).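

In this assay the group at this position is not interchangeable: bromo in place of nitro gives a 3.7-fold higher number from compound 2 to compound 3 (0.56 log units; beyond the scatter) and so weakens inhibition by a modest step beyond the scatter. Between these two groups, then, the 3-nitrophenyl form of compound 2 is the better one. Nothing available explains why this swap has this effect. As far as these compounds go, it remains open whether another group at this place, such as an amine or a nitrile, would match nitro. A single pair also leaves open whether the same swap would act alike on a different core.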